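One changed stereocentre against a cytotoxicity limit

The source may report more compounds than this note shows. Statements on the series, on what has been measured and on what is new or still open speak of the compounds shown alone.

Measured so far in an ADME assay on HFF cells (Homo sapiens) for cytotoxicity, read by neutral red uptake (on this read-out higher numbers stand for lower toxicity in this test and lower numbers for higher toxicity in this test), for two compounds:
Compound 1 `Nc1nc2c(ncn2/C=C2/C[C@H]2[C@H](O)CO)c(=O)[nH]1` gives > 300000 nM
Compound 2 `Nc1ncnc2c1ncn2/C=C1\C[C@@H]1[C@@H](O)CO` gives > 300000 nM

Compound 1 gives > 300000 nM in this assay, which is a limit and not a number. Compound 2 gives > 300000 nM, which is also a limit. Together they show the limit of > 300000 nM in this assay, at which 2 of the 2 values shown sit, in the data so far. Going by the values given here, no exact value has been reported yet, and no measured step between two compounds is available to show how large a structural change might be.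

The next compound is compound 3 `Nc1nc2c(ncn2/C=C2/C[C@@H]2[C@H](O)CO)c(=O)[nH]1`. Its difference from compound 1 is the two compounds have the same atoms and bonds and differ only in configuration as drawn: 1 of 3 stereo elements differ; a stereocentre at a saturated ring carbon is drawn R in compound 1 and S in compound 3 here, so only the drawn configuration changes.

With a single stereocentre changed, no shift beyond the scatter is expected in this assay, in either direction. The only anchor is the limit of compound 1 , > 300000 nM, and compound 3 may well return a limit too. The estimated step of a number no higher from compound 1 to compound 3 (the limit leaves the size open) is expected to stay within the scatter. For compound 3 the estimate is 300000 nM, with an expected range from 150000 nM to 600000 nM in this test.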

Compound 3, half-maximal cytotoxic concentration: > 300000 nM
Compound 3: no number, only a limit; the forecaster's own chance of this, stated with the estimate: 85%; the middle value lies on the limit itself.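

Compound 1 and compound 3 each give only a limit in this assay, so the step between them cannot be read. The compounds shown leave open the exact half-maximal cytotoxic concentration of each compound, and whether the one changed stereocentre makes any difference in this test: the limit of > 300000 nM in this assay, at which 3 of the 3 values shown sit.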